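Thiophene for Furan across Two Related Cores

The source may hold more compounds than are shown below. What is called first, only, known or untested is meant among the compounds shown, and "the series" means these compounds.

Of the compounds shown here, three have been measured in an assay on CHO cells for displacement of a labelled ligand from adenosine receptor A1 (Homo sapiens), with a stated time of 60 min, tested at 10 uM; a lower number here means less inhibition, a higher number more inhibition at the concentration tested (going by the name of the read-out). Compound 1 `CC1=C(C(=O)OC(C)C)C(c2ccoc2)NC(=S)N1` gives 18%, compound 2 `CCOC(=O)C1=C(C)N(C)C(=O)NC1c1ccoc1` gives 17%, and compound 3 `CC1=C(C(=O)OC(C)C)C(c2ccsc2)NC(=S)N1` gives 16%. All three numbers lie within the scatter of one another, so no order among them can be read from these data.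

Compound 1 and compound 3 differ in one place: thiophen-3-yl in place of furan-3-yl on a saturated ring carbon. The step of a number 2 percentage points lower from compound 1 to compound 3 (within the scatter) is within the scatter. Compound 2 has a different core from compound 1; the difference between the two cores is not broken down here.

Compound 4 `CCOC(=O)C1=C(C)N(C)C(=O)NC1c1ccsc1` has not yet been measured in this assay. It stands to compound 2 as compound 3 stands to compound 1: thiophen-3-yl in place of furan-3-yl on a saturated ring carbon. The surroundings are not identical, since in compound 2 the saturated ring carbon sits next to the ring atom that bears an ethoxycarbonyl group and three ring bonds from the ring atom that bears a methyl group, whereas in compound 1 it sits next to the ring atom that bears an isopropoxycarbonyl group; it is therefore the same kind of change, not the same one.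

In this assay compound 4 is expected to give 15%, with a likely range from 5% to 27%. The expected step of a number 2 percentage points lower from compound 2 to compound 4 (within the scatter) rests on the earlier step of a number 2 percentage points lower from compound 1 to compound 3 (within the scatter) being within the scatter and on compound 2 giving 17%. The measured value will show whether this holds for compound 4.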

Compound 4, a percentage reported as inhibition, at one concentration (the size of the read-out at that concentration, not a potency): 30%
For compound 4 the middle estimate is 15 percentage points below the measured one, outside the stated range (above it).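

In this assay, thiophen-3-yl in place of furan-3-yl on a saturated ring carbon gives a number 13 percentage points higher from compound 2 to compound 4 (beyond the scatter), and this step does not match the one seen on the core of compound 1: the same change on two cores in this assay, a number 2 percentage points lower (within the scatter) from compound 1 to compound 3 and a number 13 percentage points higher (beyond the scatter) from compound 2 to compound 4, 15 percentage points apart, beyond the scatter of two such steps The change therefore cannot be carried from one core to the other in this series with its size intact, and thiophen-3-yl cannot be called a general gain over furan-3-yl, as the pair of compound 1 and compound 3 goes against that reading. The result does not show which feature of the core of compound 2 goes with the higher number, as the two cores differ in more than one place, including ethoxycarbonyl against isopropoxycarbonyl, and two pairs read at a single concentration say nothing about potency.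

The compounds shown leave open whether the ester alone or the rest of the core decides the outcome of this change, a question that swapping only ethoxycarbonyl for isopropoxycarbonyl on the core of compound 4 would address. They also leave open how the same core behaves with a phenyl ring on the saturated ring carbon, or with a carboxylic acid in place of the ester.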